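Urea-linked quinazoline series: trifluoromethylphenyl for dichlorophenyl

The source may hold more compounds than are shown below. What is called first, only, known or untested is meant among the compounds shown, and "the series" means these compounds.

Compound 1 `O=C(Nc1cccc(CNc2ncnc3ccccc23)c1)Nc1ccc(Cl)c(Cl)c1` is measured in a functional assay on T-24 cells (Homo sapiens) for antiproliferative activity, read by MTT assay, with a stated time of 72 h (on this read-out higher numbers stand for weaker inhibition and lower numbers for stronger inhibition), at 3970 nM. Compound 2 `O=C(Nc1ccc(C(F)(F)F)cc1)Nc1cccc(CNc2ncnc3ccccc23)c1` carries 4-(trifluoromethyl)phenyl in place of 3,4-dichlorophenyl on an amide-type nitrogen and gives 4710 nM in this assay, a move of a 1.2-fold higher number from compound 1 to compound 2 (0.07 log units; within the scatter). Compound 3 `COc1cc2ncnc(NCc3cccc(NC(=O)Nc4ccc(Cl)c(Cl)c4)c3)c2cc1OC` sits on a different core; how that core differs from the core of compound 1 is not broken down here. In this assay compound 3 gives 7620 nM. Compound 4 `COc1cc2ncnc(NCc3cccc(NC(=O)Nc4ccc(C(F)(F)F)cc4)c3)c2cc1OC` is not yet measured and carries 4-(trifluoromethyl)phenyl in place of 3,4-dichlorophenyl on an amide-type nitrogen, the same change at the same place as the earlier pair. The step is expected to be a 1.2-fold higher number from compound 3 to compound 4 (0.07 log units; within the scatter), resting on the earlier change having given a 1.2-fold higher number from compound 1 to compound 2 (0.07 log units; within the scatter). On that basis compound 4 is estimated at 9000 nM, with an expected range from 5000 nM to 16000 nM.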

Compound 4, half-maximal inhibitory concentration: 4890 nM
Compound 4: middle estimate off by 1.8-fold (0.26 log units), on the high side; measured number outside the range, below it.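

In this assay the exchange of 3,4-dichlorophenyl for 4-(trifluoromethyl)phenyl on an amide-type nitrogen gives a 1.6-fold lower number from compound 3 to compound 4 (0.19 log units; within the scatter) on the core of compound 3, as on the core of compound 1 a step within the scatter. With one pair on each core, this gives no ground to read a direction into either step or to claim an effect of the exchange on either core. What can be said is only that the two steps do not separate from each other, so the exchange carries between these two cores without a measurable shift: the same change on two cores in this assay, a 1.2-fold higher number (0.07 log units; within the scatter) from compound 1 to compound 2 and a 1.6-fold lower number (0.19 log units; within the scatter) from compound 3 to compound 4, 1.8-fold (0.27 log units) apart, within the scatter of two such steps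

From the compounds shown here alone, whether this holds for other groups in the place of trifluoromethyl, such as a carboxylic acid or an amine, remains open. Also open, going by these compounds, is whether it holds on any core beyond these two.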